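Aryl Swaps at the Core of Compound 3

The compounds below may be only part of what the source reports. "The series", "measured", "known", "first", "only" and "open" are said of these compounds alone.

Compound 1 `Oc1cccc(-c2cc(-c3ccc(Cl)cc3)nc(-c3ccccn3)c2)c1`: 8090 nM
Compound 2 `Oc1cccc(-c2cc(-c3ccc(Cl)cc3)nc(-c3ccsc3)c2)c1`: 11600 nM
Compound 3 `Oc1cccc(-c2cc(-c3ccccc3)nc(-c3ccc(Cl)cc3)c2)c1`: 11200 nM

In a functional assay on DU-145 cells (Homo sapiens) for cytotoxicity, read by CCK-8 assay and cell counting, with a stated time of 2 days (on this read-out higher numbers stand for weaker inhibition and lower numbers for stronger inhibition), compound 3 stands second highest of the three numbers; its nearest neighbour is compound 2, and its furthest is compound 1, both separated from it by steps within the scatter. Compound 4 `Oc1cccc(-c2cc(-c3ccncc3)nc(-c3ccc(Cl)cc3)c2)c1` differs from compound 3 in one place: pyridin-4-yl in place of phenyl on an aromatic carbon. Within the data shown here, the steps that bear on this change are the earlier swaps of the aromatic group at the same position, a 1.4-fold higher number from compound 1 to compound 3 (0.14 log units; within the scatter), a 1.0-fold lower number from compound 2 to compound 3 (0.02 log units; within the scatter) and a 1.4-fold higher number from compound 1 to compound 2 (0.16 log units; within the scatter), none of which moved beyond the scatter. Compound 4 is therefore expected to give a number close to that of compound 3, with the step of a 1.2-fold lower number from compound 3 to compound 4 (0.07 log units; within the scatter) staying within the scatter. The estimate for compound 4 in this assay is 9500 nM, ranging from 4000 nM to 25000 nM.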

Compound 4, half-maximal inhibitory concentration: 2510 nM
Compound 4: the middle estimate sits 3.8-fold (0.58 log units) above what was measured, and the stated range ends above it.
By their numbers in this assay, from the lowest: compound 4; then compounds 1, 3 and 2 (each within the scatter of the next).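

In this assay, among these compounds, swaps at this position had so far stayed within the scatter, but pyridin-4-yl breaks that flat picture with a 4.5-fold lower number from compound 3 to compound 4 (0.65 log units; beyond the scatter), and it also separates from thiophen-3-yl with a 4.6-fold lower number from compound 2 to compound 4 (0.66 log units; beyond the scatter) and from pyridin-2-yl with a 3.2-fold lower number from compound 1 to compound 4 (0.51 log units; beyond the scatter). A ring nitrogen alone does not mark the change, as compound 1 carries pyridin-2-yl and stays within the scatter of compound 3. Nothing available explains why this change lowers the number. Still open, from the compounds shown here alone, is whether pyridin-3-yl, or a ring bearing an amine or a carboxylic acid, would side with compound 4 or with compound 3.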